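Replacing the hydroxyethyl group with a carboxylic acid

A few compounds are considered here, and "the series" means these few. Any claim that something is new, unique, unknown or untested is made for them only; others in the source may bear on it.

Measured compounds:
compound 1, `C[C@@H](O)Cc1cc(-c2ccnc3[nH]nc(C(F)(F)F)c23)cc(C2(C#N)CC2)c1`, 42% in an ADME assay on S9 fraction from liver (Rattus norvegicus) for metabolic stability, read by LC-MS, using NADPH, with a stated time of 60 min, tested at 10 uM; on this read-out higher numbers stand for a more stable compound and lower numbers for a less stable compound
compound 2, `CCC(O)Cc1cc(-c2ccnc3[nH]nc(C(F)(F)F)c23)cc(C2(C#N)CC2)c1`, 17%
compound 3, `COCCc1cc(-c2ccnc3[nH]nc(C(F)(F)F)c23)cc(C2(C#N)CC2)c1`, 90%

Among these three, compound 1 stands second highest in this assay. Compound 2 sits beneath it, a number 25 percentage points lower from compound 1 to compound 2 (beyond the scatter), while compound 3 sits well above it, a number 48 percentage points higher from compound 1 to compound 3 (beyond the scatter); the gap between compound 2 and compound 3 is wider still, a number 73 percentage points higher from compound 2 to compound 3 (beyond the scatter).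

The unmeasured compound 4, `N#CC1(c2cc(CC(=O)O)cc(-c3ccnc4[nH]nc(C(F)(F)F)c34)c2)CC1`, shares the core of compound 1 and differs from it in one place: carboxy in place of 1-hydroxyethyl on a saturated chain carbon bound to an aromatic carbon.

Within the data shown here, none of the measured steps introduces a carboxy group, so no step bears directly on this change. What the three steps do show is that the read-out in this assay moves strongly, in either direction, when the group on this saturated chain carbon is altered. Given that, a shift beyond the scatter is expected for compound 4 as well, with its direction uncertain; the estimate leans toward a higher number, as a step of a number 18 percentage points higher from compound 1 to compound 4 (beyond the scatter). For compound 4 the expected value in this assay is 60%, within a range from 30% to 90%.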

Compound 4, percent of the compound remaining: 95%
Beside the measured number, compound 4's estimate is 35 percentage points below it; the whole stated range lies below it.
By their numbers in this assay, from the lowest: compound 2; then compound 1; then compounds 3 and 4 (each within the scatter of the next).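

In this assay, the carboxy group on a saturated chain carbon bound to an aromatic carbon gives a large step up from the 1-hydroxyethyl group (a number 53 percentage points higher from compound 1 to compound 4 (beyond the scatter)) and from the 1-hydroxypropyl group (a number 78 percentage points higher from compound 2 to compound 4 (beyond the scatter)), while the step from the methoxymethyl group (a number 5 percentage points higher from compound 3 to compound 4 (within the scatter)) adds no separation between those two. The change from 1-hydroxyethyl to carboxy leaves the counts of heavy atoms, hydrogen-bond donors and hydrogen-bond acceptors the same, so those counts do not tell the two groups apart here, and across the four compounds the two hydroxyalkyl groups lie under both methoxymethyl and carboxy, with none of the four going against this. Nothing available here accounts for this pattern.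

Going by these compounds, whether a primary amide, a methyl ester or an amine at this place would also stay with compound 3 and compound 4, rather than with compound 1 and compound 2, remains open. So does the effect of a longer chain carrying the carboxylic acid.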